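The source may report more compounds than this note shows. Statements on the series, on what has been measured and on what is new or still open speak of the compounds shown alone.

Working notes on the series.

Compound 1 `COc1cc(Cl)cc(-c2nn(-c3cccc(NC(=O)Nc4ccc(Cl)c(C(F)(F)F)c4)c3)cc2-c2ccncc2)c1` and compound 2 `COc1cc(Cl)cc(-c2nn(-c3cccc(NC(=O)Nc4cccc(C(F)(F)F)c4)c3)cc2-c2ccncc2)c1` share one core and differ only in a single aromatic substituent. In a functional assay on COLO 205 cells (Homo sapiens) for inhibition, read by sulforhodamine B assay, with a stated time of 48 h, tested at 1 uM (on this read-out higher numbers stand for a weaker effect at the one concentration tested and lower numbers for a stronger effect), compound 1 gives 80%, and in the same assay compound 2 gives 79%. For the measured compounds named here, the one measured step, a number 1 percentage points lower from compound 1 to compound 2 (within the scatter), is within the scatter, so the two numbers are not ranked against each other. On the numbers in hand compound 2 stands as the lowest of two, with compound 1 nearest and within the scatter.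

Compound 3 `COc1cc(Cl)cc(-c2nn(-c3cccc(NC(=O)c4cccc(C(F)(F)F)c4)c3)cc2-c2ccncc2)c1` differs from compound 2 by 3-(trifluoromethyl)phenyl in place of (3-(trifluoromethyl)phenyl)amino on a carbonyl carbon. Going by the values given here, no measured step bears on this change: the only step recorded, the exchange of chloro for hydrogen, is of a different kind and was itself within the scatter, so it gives no size to carry over. With one donor removed at the carbonyl carbon and nothing measured for a change of this sort, no step beyond the scatter is expected in either direction; the estimated step is a number 1 percentage points higher from compound 2 to compound 3 (within the scatter). For compound 3 the expected value in this assay is 80%, with a range from 60% to 96%.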

Compound 3, a percentage reported as activity, at one concentration (the size of the read-out at that concentration, not a potency): 94%
Compound 3: the middle estimate sits 14 percentage points below what was measured; the range from low to high includes it.
By their numbers in this assay, from the lowest: compounds 2 and 1 (each within the scatter of the next); then compound 3.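

For the compounds shown here, on the carbonyl carbon, 3-(trifluoromethyl)phenyl in place of (3-(trifluoromethyl)phenyl)amino gives a number 15 percentage points higher from compound 2 to compound 3 (beyond the scatter) in this assay, the first step beyond the scatter, and the direction is towards a weaker effect at the one concentration tested. The step of a number 14 percentage points higher from compound 1 to compound 3 (beyond the scatter), with (4-chloro-3-(trifluoromethyl)phenyl)amino as the group that leaves, is also beyond the scatter and runs the same way, so this place on the carbonyl carbon responds to the exchange whichever of the two amino groups is replaced, whereas the chloro exchange elsewhere on that ring gave no step beyond the scatter. Nothing at hand bears on what lies behind this step.

The compounds shown do not separate the removal of the amide-type nitrogen with its hydrogen from any other difference between the two groups; a (3-(trifluoromethyl)phenyl)methyl group or a 3-(trifluoromethyl)phenoxy group on the same carbonyl carbon would bear on that. Also open, on these data alone, is how the step reads in a full concentration series, since each number here comes from a single concentration.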